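From Piperazin-1-yl to (6-Aminohexyl)amino on the Shared Core

This account rests on a few compounds, and the source may have more. Where it says the series, first, only, none or still open, it means among the compounds named here.

Measured compounds:
compound 1 `Nc1ccc(Nc2c(C(=O)NCc3ccc(F)cc3)nc(Br)c3cccnc23)cc1`, which in a functional assay on LNCaP cells (Homo sapiens) for cytotoxicity, read by MTT assay, with a stated time of 72 h (a higher number here means a weaker inhibitor, a lower number a stronger inhibitor), gives 7000 nM
compound 2 `N[C@H]1CC[C@H](Nc2c(C(=O)NCc3ccc(F)cc3)nc(Br)c3cccnc23)CC1`, which in this assay gives 5000 nM
compound 3 `O=C(NCc1ccc(F)cc1)c1nc(Br)c2cccnc2c1N1CCNCC1`, which in this assay gives 4500 nM

Compound 3 has the lowest of the three numbers, yet the steps of a 1.6-fold lower number from compound 1 to compound 3 (0.19 log units; within the scatter) and a 1.1-fold lower number from compound 2 to compound 3 (0.05 log units; within the scatter) both lie within the scatter, so the three compounds stand level. Compound 4 `NCCCCCCNc1c(C(=O)NCc2ccc(F)cc2)nc(Br)c2cccnc12` differs from compound 3 in one place: (6-aminohexyl)amino in place of piperazin-1-yl on an aromatic carbon. Within the data shown here, the steps that bear on this exchange are a 1.4-fold lower number from compound 1 to compound 2 (0.15 log units; within the scatter), a 1.6-fold lower number from compound 1 to compound 3 (0.19 log units; within the scatter) and a 1.1-fold lower number from compound 2 to compound 3 (0.05 log units; within the scatter); each swapped the group at this same position and none moved beyond the scatter. The step to compound 4 is therefore expected to be small, in no set direction, no change at the digits printed from compound 3 to compound 4 (within the scatter). Compound 4 is estimated at 4500 nM, with a range from 1500 nM to 14000 nM.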

Compound 4, half-maximal inhibitory concentration: 8000 nM
Compound 4: middle estimate off by 1.8-fold (0.25 log units), on the low side; the range from low to high includes it.
By their numbers in this assay, from the lowest: compounds 3, 2, 1 and 4 (each within the scatter of the next).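

Among these compounds, replacing the ring-bearing groups of the earlier compounds with the ring-free (6-aminohexyl)amino still leaves every step at this position within the scatter in this assay: a 1.8-fold higher number from compound 3 to compound 4 (0.25 log units; within the scatter), a 1.6-fold higher number from compound 2 to compound 4 (0.20 log units; within the scatter) and a 1.1-fold higher number from compound 1 to compound 4 (0.06 log units; within the scatter). All four compounds therefore stand level, so a ring in this group is not required for a number in this range. No evidence is available to account for this result. The compounds shown leave open whether a longer chain would move the number beyond the scatter. They also leave open what a carboxylic acid in place of the chain's amine would do.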